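The compounds below may be only part of what the source reports. "The series", "measured", "known", "first", "only" and "open" are said of these compounds alone.

Compound 3 `Cc1cc(C)cc(NC(=O)Nc2cc(C(C)(C)C)nn2-c2ccccc2)c1` stands lowest of the three numbers in an assay on isolated protein for inhibition of serine/threonine-protein kinase 10 (Homo sapiens), read by thermal shift assay, tested at 10 uM; on this read-out higher numbers stand for stronger stabilisation of the target against heat and lower numbers for weaker stabilisation of the target: compound 3 gives -0.3 degrees C, while compound 1 `Cc1ccccc1NC(=O)Nc1cc(C(C)(C)C)nn1-c1ccccc1` gives 8.6 degrees C and compound 2 `CC(C)(C)c1cc(NC(=O)Nc2ccc(F)cc2)n(-c2ccccc2)n1` gives 6.5 degrees C. Compound 4 `CC(C)(C)c1cc(NC(=O)Nc2ccc(F)c(F)c2)n(-c2ccccc2)n1` carries 3,4-difluorophenyl in place of 3,5-dimethylphenyl on an amide-type nitrogen. The measured step that bears most directly on it is a number 6.8 degrees C lower from compound 2 to compound 3 (beyond the scatter), where 4-fluorophenyl gave way to 3,5-dimethylphenyl; a number 8.9 degrees C lower from compound 1 to compound 3 (beyond the scatter) was larger still, and a number 2.1 degrees C lower from compound 1 to compound 2 (beyond the scatter) kept the 2-methylphenyl and 4-fluorophenyl analogues far closer together. Returning from 3,5-dimethylphenyl to a fluorinated phenyl is therefore expected to undo most of that loss in this assay, a large step upward. Compound 4 is expected to give 5.5 degrees C, in the range 2 degrees C to 8.5 degrees C. That estimate means an expected step of a number 5.8 degrees C higher from compound 3 to compound 4 (beyond the scatter).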

Compound 4, shift of the target's melting temperature: 3.4 degrees C
Compound 4: the middle estimate sits 2.1 degrees C above what was measured; the range from low to high includes it.
By their numbers in this assay, from the lowest: compound 3; then compound 4; then compound 2; then compound 1.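

In this assay, adding a further fluoro to the 4-fluorophenyl group lowers the number rather than raising it (a number 3.1 degrees C lower from compound 2 to compound 4 (beyond the scatter)), so more fluoro on this ring does not bring more stabilisation within this pair. 3,4-Difluorophenyl recovers only part of the ground lost with 3,5-dimethylphenyl (a number 3.7 degrees C higher from compound 3 to compound 4 (beyond the scatter)) and remains short of 2-methylphenyl (a number 5.2 degrees C lower from compound 1 to compound 4 (beyond the scatter)). No available evidence accounts for these differences.

Open, on these data alone, is how 2-chlorophenyl, 2-fluorophenyl or a pyridyl ring on the amide-type nitrogen would compare with compound 1 and compound 2.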